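Amide to urea on a sulfonate ester scaffold

The source may report more compounds than this note shows. Statements on the series, on what has been measured and on what is new or still open speak of the compounds shown alone.

Compound 1 `CCC(=O)Nc1cccc(S(=O)(=O)Oc2ccccc2C(C)C)c1` gives 14000 nM in a functional assay on MCF7 cells (Homo sapiens) for antiproliferative activity, read by sulforhodamine B assay, with a stated time of 48 h; a higher number here means a weaker inhibitor, a lower number a stronger inhibitor.
Compound 2 `CCCC(=O)Nc1ccc(S(=O)(=O)Oc2ccccc2C(C)C)cc1` gives 6600 nM in this assay.
Compound 3 `CCCC(=O)Nc1ccc(S(=O)(=O)Oc2ccccc2I)cc1` gives 9700 nM in this assay.

Compound 3 stands second highest of the three numbers. Its nearest neighbour is compound 1, and its furthest is compound 2; both gaps are within the scatter, so the three compounds cannot be told apart on these numbers. Among the compounds with values here, the single step among the measured compounds is a 1.5-fold higher number from compound 2 to compound 3 (0.17 log units; within the scatter), which exchanges one group on the aromatic ring for another and leaves the number essentially unchanged.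

Compound 4 `CCCNC(=O)Nc1ccc(S(=O)(=O)Oc2ccccc2I)cc1` differs from compound 3 in one place: propylamino in place of propyl on a carbonyl carbon. This turns the propylcarbonyl amino group into a propylcarbamoyl amino group, adding one hydrogen-bond donor. Within the data shown here, no measured step touches the carbonyl carbon, so nothing among the measured compounds speaks directly to this change. Among the measured compounds shown here, the only step available, a 1.5-fold higher number from compound 2 to compound 3 (0.17 log units; within the scatter), concerns a different part of the molecule and was within the scatter. With no evidence for a shift in either direction, the step of a 1.1-fold lower number from compound 3 to compound 4 (0.03 log units; within the scatter) is expected to stay within the scatter. Compound 4 is therefore estimated at 9000 nM, with a range from 3500 nM to 25000 nM.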

Compound 4, half-maximal inhibitory concentration: 2900 nM
Compound 4: middle estimate off by 3.1-fold (0.49 log units), on the high side, outside the stated range (below it).
By their numbers in this assay, from the lowest: compound 4; then compounds 2, 3 and 1 (each within the scatter of the next, the first and the last beyond it).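

Placing propylamino instead of propyl on the carbonyl carbon gives a 3.3-fold lower number from compound 3 to compound 4 (0.52 log units; beyond the scatter) in this assay. Within the data shown here, this shows that the position can move the number, which the only earlier step, a 1.5-fold higher number from compound 2 to compound 3 (0.17 log units; within the scatter), made at a different place in the molecule, did not show for its own change. The change is small in atoms, turning the (propylcarbonyl)amino group into the (propylcarbamoyl)amino group with one added hydrogen-bond donor, but no measurement shown here explains the shift.

The compounds shown leave open whether the lower number depends on the hydrogen of the new nitrogen, which a dimethylamino group on the same carbonyl carbon would test, and whether chain length matters, which a longer chain such as butylamino would show. They also leave open whether the same exchange would give a similar step with isopropyl in place of iodo on the aromatic carbon, as in compound 2, since this single pair carries iodo.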